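From Methylsulfonyl to Sulfamoyl on a Lost Binder

A few compounds are considered here, and "the series" means these few. Any claim that something is new, unique, unknown or untested is made for them only; others in the source may bear on it.

Compound 3 `CC(=O)/C(=N\c1cccc(Cl)c1)NNc1ccccc1S(C)(=O)=O` is one of three measured compounds in this set. In an assay on isolated protein for binding affinity to corticotropin-releasing factor receptor 1 (Homo sapiens) (on this read-out lower numbers stand for stronger inhibition and higher numbers for weaker inhibition), compound 3 gives only a limit, > 10000 nM. Compound 1 `CC(=O)/C(=N\c1cccc(Cl)c1)NNc1ccccc1[N+](=O)[O-]` carries a nitro group where compound 3 has its methylsulfonyl group, and in this assay compound 1 gives 51 nM. Compound 2 `CC(=O)/C(=N\Nc1ccccc1C)Oc1cccc(Cl)c1` gives only a limit as well, > 10000 nM. Going by the values given here, the only measured step into the position of interest is an at least 190-fold higher number from compound 1 to compound 3 (2.29 log units; beyond the scatter); it ends at the limit of > 10000 nM in this assay, at which 2 of the 3 values shown sit, so how far compound 3 truly falls is unknown. Compound 4 `CC(=O)/C(=N\c1cccc(Cl)c1)NNc1ccccc1S(N)(=O)=O` is the unmeasured compound; it differs from compound 3 by amino in place of methyl on a sulfonyl sulfur. Among the compounds with values here, no measured step alters a substituent on a sulfonyl sulfur, so the only guide is the step from compound 1 to compound 3, which lands on the limit. Compound 4 keeps the sulfonyl group that accompanied that loss, so compound 4 is expected to remain near the limit, a step that the limit leaves unreadable from compound 3 to compound 4. The estimate for compound 4 is 15000 nM, within 3000 nM to 50000 nM.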

Compound 4, inhibition constant: > 10000 nM
Compound 4: only a limit was reported; the forecaster's own chance of this, stated with the estimate: 75%; the middle value lies beyond the limit too.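

In this assay, compound 4 also gives only a limit, > 10000 nM. Sulfamoyl in place of nitro on this aromatic carbon gives an at least 190-fold higher number from compound 1 to compound 4 (2.29 log units; beyond the scatter), so sulfamoyl, like methylsulfonyl, does not keep the strong binding of compound 1. The step from compound 3 to compound 4 cannot be read, because both compounds sit at the limit: the limit of > 10000 nM in this assay, at which 3 of the 4 values shown sit.

As far as these compounds go, how far compound 3 and compound 4 truly lie past that limit stays unknown, so amino and methyl on the sulfonyl sulfur cannot be told apart here. Also open, from the compounds shown here alone, is whether a nitrile or a carboxylic acid on this aromatic carbon, or a longer chain on the sulfonyl sulfur, would bring binding back towards that of compound 1.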